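Cyclopropyl on the exocyclic amine of a carbocyclic purine

A few compounds are considered here, and "the series" means these few. Any claim that something is new, unique, unknown or untested is made for them only; others in the source may bear on it.

Compound 1 `Nc1nc(Cl)c2ncn([C@@H]3C[C@@]4(CO)CC[C@@H]3C4)c2n1` carries a chloro on an aromatic carbon of the shared core. In a functional assay on HeLa cells (Homo sapiens), with a stated time of 72 h (on this read-out higher numbers stand for weaker inhibition and lower numbers for stronger inhibition), compound 1 gives > 340000 nM, which is a limit of the assay and not a number. Compound 2 `Nc1nc(N)c2ncn([C@@H]3C[C@@]4(CO)CC[C@@H]3C4)c2n1` has amino in place of chloro at that carbon. In this assay compound 2 gives 190000 nM. This is the only number shown; the one further value is a limit. The step of an at least 1.7-fold lower number from compound 1 to compound 2 (0.25 log units; that floor lies within the scatter) has a floor that lies within the usual scatter, and the line the limit of > 340000 nM in this assay, at which 1 of the 2 values shown sits, shows how the limit sits.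

Compound 3 `Nc1nc(NC2CC2)c2ncn([C@@H]3C[C@@]4(CO)CC[C@@H]3C4)c2n1` differs from compound 2 by cyclopropyl in place of hydrogen on a nitrogen on an aromatic ring; cut one bond further out, the change reads amino to cyclopropylamino. No measured step touches a substituent on this nitrogen; the only step shown, from the chloro to the amino, is bounded by a limit and offers no size to carry over. The step of a 1.1-fold higher number from compound 2 to compound 3 (0.02 log units; within the scatter) is therefore expected to stay within the scatter, with no direction favoured. Compound 3 is estimated to give 200000 nM, within a range from 50000 nM to 700000 nM.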

Compound 3, half-maximal inhibitory concentration: 101000 nM
Compound 3: the middle estimate sits 2.0-fold (0.30 log units) above what was measured; measured number inside the range.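

In this assay, among these compounds, the first measured change on this nitrogen gives a 1.9-fold lower number from compound 2 to compound 3 (0.27 log units; within the scatter), so cyclopropyl in place of hydrogen leaves compound 2 and compound 3 indistinguishable, and the amino and cyclopropylamino groups cannot be ranked at this position. Read from the chloro, the same aromatic carbon now gives a step whose floor clears the scatter, which the step to the amino did not do: an at least 3.3-fold lower number from compound 1 to compound 3 (0.52 log units; beyond the scatter). That step remains a floor and not a size, since the value of compound 1 is a limit of the assay and not a number: the limit of > 340000 nM in this assay, at which 1 of the 3 values shown sits.

The compounds shown leave open whether a larger ring such as cyclohexyl, a longer chain such as n-butyl, or a second substituent on this nitrogen, as in dimethylamino, would produce a step beyond the scatter from compound 2. They also leave open how this series would read with a carboxylic acid in place of the hydroxymethyl group, which stays the same in all three compounds.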